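Methyl for Fluoro on a Second Sulfonyl Core

The source may report more compounds than this note shows. Statements on the series, on what has been measured and on what is new or still open speak of the compounds shown alone.

Measured compounds:
Compound 1, `CN(C)S(=O)(=O)c1ccc(F)c(C#Cc2cc(Cl)ccc2OCC(=O)O)c1`, gives 0.007 in an ADME assay on a cell-free system (plasma, Rattus norvegicus); on this read-out higher numbers stand for a larger free fraction and lower numbers for a smaller free fraction.
Compound 2, `Cc1ccc(S(=O)(=O)N(C)C)cc1C#Cc1cc(Cl)ccc1OCC(=O)O`, gives 0.004.
Compound 3, `CS(=O)(=O)c1ccc(F)c(C#Cc2cc(Cl)ccc2OCC(=O)O)c1`, gives 0.011.

Compound 4, `Cc1ccc(S(C)(=O)=O)cc1C#Cc1cc(Cl)ccc1OCC(=O)O`, has not been measured. It is made from compound 3 by the change (methyl in place of fluoro on an aromatic carbon). The same kind of change has already been made once: compound 2 comes from compound 1 by methyl in place of fluoro on an aromatic carbon, and that step gave a 1.8-fold lower number from compound 1 to compound 2 (0.24 log units; within the scatter). The two places are not the same word for word: in the first case the aromatic carbon is para to a dimethylsulfamoyl group (6 heavy atoms), in the second it is para to a methylsulfonyl group (4 heavy atoms). The two cores differ by methyl in place of dimethylamino on a sulfonyl sulfur, a change whose step was a 1.6-fold higher number from compound 1 to compound 3 (0.20 log units; within the scatter).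

Resting on compound 1 and its step of a 1.8-fold lower number from compound 1 to compound 2 (0.24 log units; within the scatter), the step from compound 3 to compound 4 is expected to be about a 1.8-fold lower number from compound 3 to compound 4 (0.26 log units; within the scatter). Compound 4 is therefore estimated at 0.006, with a range from 0.003 to 0.012.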

Compound 4, unbound fraction: 0.014
The estimate for compound 4 lay 2.3-fold (0.37 log units) below the measured number; the measured number lies above the stated range.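

Replacing fluoro with methyl on the methylsulfonyl core gives a 1.3-fold higher number from compound 3 to compound 4 (0.10 log units; within the scatter) in this assay, so on both cores this change stays within the scatter, and the two steps cannot be told apart: the same change on two cores in this assay, a 1.8-fold lower number (0.24 log units; within the scatter) from compound 1 to compound 2 and a 1.3-fold higher number (0.10 log units; within the scatter) from compound 3 to compound 4, 2.2-fold (0.35 log units) apart, within the scatter of two such steps The other change, methyl in place of dimethylamino on a sulfonyl sulfur, gives a 3.5-fold higher number from compound 2 to compound 4 (0.54 log units; beyond the scatter), and this step also cannot be told apart from its counterpart on the fluoro compounds: the same change on two cores in this assay, a 1.6-fold higher number (0.20 log units; within the scatter) from compound 1 to compound 3 and a 3.5-fold higher number (0.54 log units; beyond the scatter) from compound 2 to compound 4, 2.2-fold (0.35 log units) apart, within the scatter of two such steps These two pairs show no sign that either change depends on the core, but two cores are a small sample, and they do not show that the steps would carry over to any other core in the series.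

As far as these compounds go, it remains open whether a different group at this aromatic position, such as a methoxy or a nitrile, would shift the unbound fraction beyond the scatter. From the compounds shown here alone, it is also open whether an ethyl group on the sulfonyl sulfur would follow the same pattern as the methyl.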